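The source may report more compounds than this note shows. Statements on the series, on what has been measured and on what is new or still open speak of the compounds shown alone.

Three compounds share one core and differ only in what hangs from the urea-linked aromatic rings. Compound 1 `CNc1cc(Oc2c(F)cc(NC(=O)Nc3cccc(C(F)(F)F)c3)cc2F)ncn1` carries a trifluoromethyl on the outer ring and two fluorine atoms on the inner ring; compound 3 `CNc1cc(Oc2ccc(NC(=O)Nc3cccc(C(F)(F)F)c3)c(F)c2)ncn1` keeps the trifluoromethyl and has a single fluorine on the inner ring; compound 2 `CNc1cc(Oc2ccc(NC(=O)Nc3cccc(C(F)F)c3)cc2)ncn1` has no fluorine on the inner ring and a difluoromethyl on the outer ring. In an assay on isolated protein for inhibition of serine/threonine-protein kinase TNNI3K (Homo sapiens) (on this read-out lower numbers stand for stronger inhibition and higher numbers for weaker inhibition), compound 1 gives 20 nM, compound 3 gives 63 nM, and compound 2 gives 100 nM. Compound 2 thus has the highest number of the three, although its number and that of compound 3 lie within the usual scatter of this assay and cannot be told apart; only compound 1 stands clearly lower.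

Compound 4 `CNc1cc(Oc2ccc(NC(=O)Nc3cccc(C(C)(C)C)c3)cc2)ncn1` has not yet been measured. It differs from compound 2 in one place: tert-butyl in place of difluoromethyl on an aromatic carbon. Within the data shown here, no measured pair shows this exchange, so the expected step rests on judgement alone. The expected step from compound 2 to compound 4 in this assay is a 1.2-fold higher number from compound 2 to compound 4 (0.08 log units; within the scatter), essentially none beyond the scatter. Compound 4 is therefore estimated at 120 nM, within a range from 40 nM to 400 nM.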

Compound 4, half-maximal inhibitory concentration: 40 nM
Compound 4: middle estimate off by 3.0-fold (0.48 log units), on the high side; measured number inside the range.
By their numbers in this assay, from the lowest: compounds 1, 4, 3 and 2 (each within the scatter of the next, the first and the last beyond it).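

In this assay, tert-butyl in place of difluoromethyl gives a 2.5-fold lower number from compound 2 to compound 4 (0.40 log units; beyond the scatter), so this position on the aromatic ring tolerates a branched all-carbon group without any loss of inhibition. Compound 1, compound 2 and compound 3 all carry fluorine in the group at this position, so they could not show that a group without fluorine also works here. Nothing available explains why this exchange lowers the number.

The compounds shown leave open how a methyl, an unbranched longer chain such as butyl, or a group bearing an amine or a carboxylic acid would behave at this position. They also leave open whether tert-butyl would give a similar step alongside the fluorine atoms found elsewhere in compound 1 and compound 3.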